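Swapping a halogenated aryl ring for isopropyl: solubility outlook

The compounds below may be only part of what the source reports. "The series", "measured", "known", "first", "only" and "open" are said of these compounds alone.

Three measured compounds share one core and differ at the group hung from it. Compound 1 `COc1ccc(F)cc1CNCCCNc1ccnc2cc(Cc3ccc(F)cc3Cl)ccc12` carries a 2-chloro-4-fluorophenyl on a saturated chain carbon bound to an aromatic carbon, and in a physicochemical assay for solubility, with a stated time of 18 h, at pH 7.4 (a lower number here means a less soluble compound, a higher number a more soluble compound), compound 1 gives 4200 nM. Compound 2 `COc1cccc(CNCCCNc2ccnc3cc(Cc4ccc(C#N)cc4)ccc23)c1O` gives 4200 nM in this assay, level with compound 1 at the digits shown; together they sit lowest of the three numbers. Compound 3 `COc1cccc(CNCCCNc2ccnc3cc(-c4cc(C(F)(F)F)cc(C(F)(F)F)c4)ccc23)c1O` gives 32000 nM in this assay, a higher number than compound 1, beyond the usual scatter. Going by the values given here, no pair of measured compounds differs in only one place, so no single measured step is available to lean on.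

Compound 4 `COc1ccc(F)cc1CNCCCNc1ccnc2cc(CC(C)C)ccc12` has not yet been measured. It differs from compound 1 in one place: isopropyl in place of 2-chloro-4-fluorophenyl on a saturated chain carbon bound to an aromatic carbon. Among the compounds with values here, with no measured step of this kind to compare, the expectation rests on the loss of a six-membered aromatic ring with its fluorine and chlorine and the arrival of a three-carbon group without a ring; the step from compound 1 to compound 4 is expected to be a 2.9-fold higher number from compound 1 to compound 4 (0.46 log units; beyond the scatter), upward and beyond the scatter. In this assay compound 4 is therefore estimated at 12000 nM, with a range from 4000 nM to 40000 nM.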

Compound 4, solubility: 4200 nM
Estimate against measurement, compound 4: 2.9-fold (0.46 log units) above; measured number inside the range.
By their numbers in this assay, from the lowest: compounds 1, 2 and 4 (each within the scatter of the next); then compound 3.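

In this assay, going by these compounds alone, the one step that can be read at this position is no change at the digits printed from compound 1 to compound 4 (within the scatter), and it places the two compounds within the usual scatter of each other. Within the data shown here, with isopropyl in place of 2-chloro-4-fluorophenyl on a saturated chain carbon bound to an aromatic carbon, the loss of the six-membered aromatic ring with its fluorine and chlorine therefore shows up as no measurable difference in this read-out, on this core and at this one place, which the earlier compounds could not show, as no two of them differed in only one place. Nothing measured here accounts for this result.

Going by these compounds, whether an amine, a carboxylic acid or a longer chain at this same place would also stay within the scatter of compound 1 remains open, as does whether the same swap would read alike on the core of compound 2. The number of compound 3, 32000 nM, remains unconnected to this position, as compound 3 differs from the other compounds in more than one place and no single change can be tied to it.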